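Swapping methyl for fluoro on two related cores

The source may hold more compounds than are shown below. What is called first, only, known or untested is meant among the compounds shown, and "the series" means these compounds.

Four close relatives are compared in a functional assay on A549 cells (Homo sapiens) for cytotoxicity, read by CCK-8 assay, with a stated time of 24 h; a lower number here means a stronger inhibitor, a higher number a weaker inhibitor. Compound 1 has the structure `C/C(=C\c1cc(-c2ccc(C)cc2)cs1)C(N)=O`. In this assay compound 1 gives no number, only a limit, > 50000 nM. Compound 2, with the structure `C/C(=C\c1cc(-c2ccc(F)cc2)cs1)C(N)=O`, differs from compound 1 by fluoro in place of methyl on an aromatic carbon. In this assay compound 2 likewise reaches only a limit, > 50000 nM. The step that the two limits leave unreadable from compound 1 to compound 2 therefore cannot be sized; this follows from the limit of > 50000 nM in this assay, at which 3 of the 3 values shown sit.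

Compound 3, with the structure `C/C(=C\c1nc(-c2ccc(C)cc2)cs1)C(N)=O`, carries a different core, and how that core differs from the core of compound 1 is not broken down here. In this assay compound 3 also gives only a limit, > 50000 nM.

Compound 4, with the structure `C/C(=C\c1nc(-c2ccc(F)cc2)cs1)C(N)=O`, has not yet been measured. It differs from compound 3 by fluoro in place of methyl on an aromatic carbon, and the place of the change is the same, word for word, as in the change from compound 1 to compound 2, so it is the same change. Among the compounds with values here, for compound 1 and compound 2 that change gave a step that the two limits leave unreadable from compound 1 to compound 2, and every value measured so far sits at the limit of > 50000 nM in this assay, at which 3 of the 3 values shown sit. On that basis the step is expected to be a step that the limit leaves unreadable from compound 3 to compound 4. Compound 4 is expected to give roughly 80000 nM, most likely again only a limit, within an estimated range from 30000 nM to 300000 nM.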

Compound 4, half-maximal inhibitory concentration: 13200 nM
Compound 4: the middle estimate sits 6.1-fold (0.78 log units) above what was measured, and the stated range ends above it.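

Within the data shown here, on the second core, fluoro in place of methyl on an aromatic carbon gives an at least 3.7-fold lower number from compound 3 to compound 4 (0.57 log units; beyond the scatter) in this assay, so on this core the change comes with a lower number, and compound 4 is the only compound of the four to give a measured value rather than a limit. On the first core, compound 2, which carries the same fluoro, gives only a limit, > 50000 nM. This does not show that the change carries from one core to the other, since the matching step on the first core cannot be read and neither its size nor its direction can be set against the new step: the limit of > 50000 nM in this assay, at which 3 of the 4 values shown sit.

The compounds shown leave open whether the effect of this swap belongs to fluoro in particular or would also appear with another group at the same place, such as chloro, methoxy or an amine. They also leave open how the number would respond if the amide at the other end of the molecule gave way to a carboxylic acid or a longer chain on either core.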